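A few compounds are considered here, and "the series" means these few. Any claim that something is new, unique, unknown or untested is made for them only; others in the source may bear on it.

Measured so far:
compound 1 `CC1(C)CN(NC(=S)Nc2ccc(Cl)cc2)c2cc(Cl)ccc2O1`: > 30000 nM
compound 2 `CC1(C)CN(NC(=O)Nc2cccc(C#N)c2)c2cc(Cl)ccc2O1`: 1900 nM

Two compounds have been run in a functional assay on thoracic aorta (Rattus norvegicus); on this read-out higher numbers stand for an effect only at larger amounts of compound and lower numbers for an effect already at smaller amounts. Compound 1 sits at the limit of > 30000 nM in this assay, at which 1 of the 2 values shown sits. That value is a limit of the assay and not a number. In this assay compound 2 gives 1900 nM; this is the only number shown in the series. Within the data shown here, since compound 1 stands at a limit of the assay, no measured step between two numbers exists and the scatter of the read-out cannot be checked against a pair of this series.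

Compound 3 `CC1(C)CN(NC(=O)Nc2ccc(C#N)cc2)c2cc(Cl)ccc2O1` is the next compound to be measured. It differs from compound 2 in one place: 4-cyanophenyl in place of 3-cyanophenyl on an amide-type nitrogen. Compound 1 differs from compound 2 in more than one place and cannot serve as a guide for a change of the nitrile position alone.

Among the measured compounds shown here, with no measured step to rest on, the expectation for compound 3 in this assay is a value close to that of compound 2, and the step of a 1.3-fold higher number from compound 2 to compound 3 (0.12 log units; within the scatter) is expected to stay within the usual scatter. The estimate for compound 3 is 2500 nM, with a range from 600 nM to 12000 nM.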

Compound 3, half-maximal effective concentration: 3700 nM
Beside the measured number, compound 3's estimate is 1.5-fold (0.17 log units) below it; measured number inside the range.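

In this assay, among these compounds, the exchange of 3-cyanophenyl for 4-cyanophenyl on the amide-type nitrogen gives the first readable step: a 1.9-fold higher number from compound 2 to compound 3 (0.29 log units; within the scatter). The two nitrile placements are therefore not told apart by this read-out, and with the shared core and the carbonyl held constant, this pair shows no measurable dependence on which of the two ring positions carries the nitrile. Nothing measured in the series bears on this step or offers a reason for its size.

Compound 1 gives > 30000 nM, a limit of the assay and not a number, and as it differs from compound 2 and compound 3 in more than one place, the limit cannot be assigned to any single change, including the thiocarbonyl or the 4-chlorophenyl. Still open, as far as these compounds go, is how this place on the amide-type nitrogen responds to 2-cyanophenyl, to an unsubstituted phenyl, or to a ring carrying an amine or a carboxylic acid in place of the nitrile, and whether any such group would separate from compound 2 by more than the scatter.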